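Acetyl to isobutoxycarbonyl on compound 3

The compounds below may be only part of what the source reports. "The series", "measured", "known", "first", "only" and "open" are said of these compounds alone.

In a physicochemical assay for solubility, at pH 7.4 (on this read-out higher numbers stand for higher solubility and lower numbers for lower solubility), compound 1 (`NS(=O)(=O)c1ccc(SCCO)c(C(=O)O)c1`) reads 9300 ug/mL and compound 2 (`CC(=O)OCCS(=O)(=O)c1ccc(S(N)(=O)=O)s1`) reads 880 ug/mL on the same scale. Compound 3 (`CC(=O)OCCCS(=O)(=O)c1ccc(S(N)(=O)=O)s1`) reads 920 ug/mL and so stands level with compound 2 within the scatter, while the gap up to compound 1 lies beyond the scatter.

The next structure is compound 4 (`CC(C)COC(=O)OCCCS(=O)(=O)c1ccc(S(N)(=O)=O)s1`), which carries isobutoxy in place of methyl on a carbonyl carbon. The same difference, cut one bond further out, reads acetyl to isobutoxycarbonyl.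

Among the compounds with values here, only one measured step bears on this change. It is a 1.0-fold higher number from compound 2 to compound 3 (0.02 log units; within the scatter) and it swaps acetoxymethyl for acetoxy on a saturated chain carbon. That step alters the chain and leaves the group on the carbonyl carbon untouched, so it offers only a weak guide. Within the data shown here, no measured pair covers a change at the carbonyl carbon, and the direction here rests on judgement. A step beyond the scatter towards a lower number is expected in this assay for this pair. The estimated move is a 7.7-fold lower number from compound 3 to compound 4 (0.88 log units; beyond the scatter) on present data. For compound 4 the expected value is 120 ug/mL with an estimated range of 30 ug/mL to 450 ug/mL as the working figure.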

Compound 4, solubility: 80 ug/mL
Compound 4: the middle estimate sits 1.5-fold (0.18 log units) above what was measured; the range from low to high includes it.
By their numbers in this assay, from the lowest: compound 4; then compounds 2 and 3 (each within the scatter of the next); then compound 1.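

Working notes on the series: in this assay, isobutoxy in place of methyl on a carbonyl carbon gives a 12-fold lower number from compound 3 to compound 4 (1.06 log units; beyond the scatter), the first single-place step in the series to lie beyond the scatter. The only earlier step, at the saturated chain carbon, gave a 1.0-fold higher number from compound 2 to compound 3 (0.02 log units; within the scatter) and left the group on the carbonyl carbon unchanged, so the carbonyl carbon is now the one position shown to move this read-out, on the strength of a single pair. No measurement at hand accounts for the size of the step, and nothing separates the part played by the added oxygen from that of the four carbons of isobutoxy.

Going by these compounds, whether methoxy, ethoxy or an amine on the same carbonyl carbon would give a step of similar size remains open, and so does the point along that series at which the number falls. Also open, on these data alone, is whether isobutoxy on the carbonyl carbon would give a comparable step with the chain of compound 2, which would show if the change carries over from one chain to the other.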